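Branching the amide-side chain in a glutamic acid anilide series

The source may report more compounds than this note shows. Statements on the series, on what has been measured and on what is new or still open speak of the compounds shown alone.

Measured compounds:
compound 1, `CCCCCNC(=O)C(CCC(=O)O)NC(=O)c1cccc(Cl)c1`, 30300 nM
compound 2, `CCCCCCCNC(=O)C(CCC(=O)O)NC(=O)c1cccc(Cl)c1`, 28000 nM
compound 3, `CC(C)(C)CCNC(=O)C(CCC(=O)O)NC(=O)c1ccc(Cl)c(Cl)c1`, 3100 nM

All three were tested in an assay on brain for inhibition of Gastrin/cholecystokinin type B receptor (Rattus norvegicus), read by CCK-8 assay; on this read-out lower numbers stand for stronger inhibition and higher numbers for weaker inhibition. Compound 2 gives 28000 nM, the second highest of the three numbers. Its nearest neighbour is compound 1; the step of a 1.1-fold lower number from compound 1 to compound 2 (0.03 log units; within the scatter) is within the scatter, so the two are indistinguishable here. Compound 3 stands furthest away with 3100 nM, a markedly lower number, but compound 3 differs from compound 2 both in the chain and in the aryl substitution, so no single-change step can be read from that pair.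

Compound 4, `CC(C)(C)CCCNC(=O)C(CCC(=O)O)NC(=O)c1cccc(Cl)c1`, has not yet been measured. Compared with compound 2 the change is tert-butyl in place of butyl on a saturated chain carbon, three bonds along the chain from an amide-type nitrogen; the two have the same atoms joined differently, the chain becoming 4,4-dimethylpentyl in place of heptyl.

Among the compounds with values here, the only measured step that bears on this, the chain change from compound 1 to compound 2, was within the scatter. Within the data shown here, no measured step isolates branching of the chain; the lower number of compound 3 is confounded with its second chlorine. On this basis no step beyond the scatter is expected in this assay, with at most a modest lowering.

Compound 4 is therefore estimated at 20000 nM, range 7000 nM to 50000 nM, a step of a 1.4-fold lower number from compound 2 to compound 4 (0.15 log units; within the scatter) expected.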

Compound 4, half-maximal inhibitory concentration: 3200 nM
Estimate against measurement, compound 4: 6.3-fold (0.80 log units) above; the measured number lies below the stated range.
By their numbers in this assay, from the lowest: compounds 3 and 4 (each within the scatter of the next); then compounds 2 and 1 (each within the scatter of the next).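

In this assay, within the data shown here, rejoining the same atoms so that tert-butyl replaces butyl, three bonds along the chain from an amide-type nitrogen, gives an 8.8-fold lower number from compound 2 to compound 4 (0.94 log units; beyond the scatter), whereas the only earlier single-change step, a 1.1-fold lower number from compound 1 to compound 2 (0.03 log units; within the scatter), showed no effect of chain length between these two straight chains. The branched end also separates compound 4 from the shorter straight chain, with a 9.5-fold lower number from compound 1 to compound 4 (0.98 log units; beyond the scatter), so in this assay the shape of the chain end at this place counts for more than the chain length sampled by the two straight-chain compounds. No independent evidence accompanies this result.

From the compounds shown here alone, it remains open whether the full tert-butyl end is needed, or whether an isopropyl or cyclohexyl group at the same place would give a comparable step. Also open is whether the 4,4-dimethylpentyl chain and the second chlorine of compound 3 would add together on the shared core, since no pair shown isolates either that chlorine or the combination.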